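Aryl ketone swaps on the shared core: compound 4

The source may report more compounds than this note shows. Statements on the series, on what has been measured and on what is new or still open speak of the compounds shown alone.

Compound 1 `COc1cc(-c2nnc3n2NC(c2ccco2)C(C(=O)c2ccc(F)c(F)c2)S3)cc(OC)c1OC` is the anchor of this set. In a functional assay on MCF7 cells (Homo sapiens) for cytotoxicity, read by MTT assay, with a stated time of 48 h (on this read-out higher numbers stand for weaker inhibition and lower numbers for stronger inhibition), compound 1 gives 73200 nM, the lowest of the two numbers shown here, with compound 2 `COc1cc(-c2nnc3n2NC(c2ccco2)C(C(=O)c2cccc(Br)c2)S3)cc(OC)c1OC` nearest at 91800 nM. Compound 3 `COc1cc(-c2nnc3n2NC(c2ccco2)C(C(=O)c2ccc(-c4ccccc4)cc2)S3)cc(OC)c1OC` only reaches the limit of this assay, > 100000 nM; that is a limit, not a number (the limit of > 100000 nM in this assay, at which 1 of the 3 values shown sits). The measured steps on the carbonyl carbon, a 1.3-fold higher number from compound 1 to compound 2 (0.10 log units; within the scatter) and an at least 1.3-fold higher number from compound 1 to compound 3 (0.13 log units; that floor lies within the scatter), both stay within the scatter. Compound 4 `COc1cccc(C(=O)C2Sc3nnc(-c4cc(OC)c(OC)c(OC)c4)n3NC2c2ccco2)c1` differs from compound 1 by 3-methoxyphenyl in place of 3,4-difluorophenyl on a carbonyl carbon. With both measured steps flat, no change beyond the scatter is expected in this assay: the expected step is a 1.1-fold higher number from compound 1 to compound 4 (0.04 log units; within the scatter). Compound 4 is estimated at 80000 nM, in the range 40000 nM to 160000 nM.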

Compound 4, half-maximal inhibitory concentration: > 100000 nM
Compound 4 gave a limit, no number; the forecaster's own chance of this, stated with the estimate: 30%; middle value at least 1.2-fold (0.09 log units) away from the limit.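

Compound 4 joins compound 3 at a limit of this assay rather than a number: the limit of > 100000 nM in this assay, at which 2 of the 4 values shown sit. The readable steps of an at least 1.3-fold higher number from compound 1 to compound 4 (0.13 log units; that floor lies within the scatter) and an at least 1.0-fold higher number from compound 2 to compound 4 (0.03 log units; that floor lies within the scatter) do not separate 3-methoxyphenyl from 3,4-difluorophenyl or 3-bromophenyl on the carbonyl carbon, and the step between the two limits cannot be read. A methoxy group, with its hydrogen-bond acceptor, thus adds no step beyond the scatter at this position.

Going by these compounds, whether any group here can move the read-out beyond the scatter stays open. An aminophenyl, a carboxyphenyl or a saturated alkyl chain at this position would bear on that.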